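The source may report more compounds than this note shows. Statements on the series, on what has been measured and on what is new or still open speak of the compounds shown alone.

Compound 3 `C=C(Br)C(=O)Nc1cccc(-c2cn3nc(Cc4ccc(OC)cc4)sc3n2)c1` gives the lowest number of the three measured in a functional assay on HeLa cells (Homo sapiens) for inhibition, read by cell counting, with a stated time of 4 days (a lower number here means a stronger inhibitor, a higher number a weaker inhibitor), at 2300 nM. Compound 2 `Nc1cccc(-c2cn3nc(Cc4ccc(Cl)cc4)sc3n2)c1` gives 25000 nM and compound 1 `COc1ccc(-c2nn3cc(-c4cccc(N)c4)nc3s2)cc1OC` gives 26000 nM; both gaps to compound 3 lie beyond the scatter. Compound 4 `C=C(Br)C(=O)Nc1cccc(-c2cn3nc(-c4ccc(OC)cc4)sc3n2)c1` awaits measurement in this assay. It differs from compound 3 in one place: 4-methoxyphenyl in place of 4-methoxybenzyl on an aromatic carbon. Among the compounds with values here, no measured pair isolates this exchange; compound 1 and compound 2 differ from each other in more than one place, and their two values sit close together, which is weak ground but gives no sign of a large effect. The step of a 1.3-fold higher number from compound 3 to compound 4 (0.12 log units; within the scatter) is therefore estimated as small, within or near the scatter, in either direction. Compound 4 is expected at 3000 nM, in the range 1000 nM to 9000 nM.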

Compound 4, half-maximal inhibitory concentration: 2300 nM
Compound 4: the middle estimate sits 1.3-fold (0.12 log units) above what was measured; low and high end bracket the measured number.
By their numbers in this assay, from the lowest: compounds 3 and 4 (each within the scatter of the next); then compounds 2 and 1 (each within the scatter of the next).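

In this assay, within the data shown here, the exchange of 4-methoxybenzyl for 4-methoxyphenyl gives no change at the digits printed from compound 3 to compound 4 (within the scatter) on this aromatic carbon, the first reading that isolates this position. With the rest of the structure held constant, the methylene link between this carbon and the methoxy-bearing ring can be removed without a change beyond the scatter. No supporting data on hand bear on this result. Still open, as far as these compounds go, is how a longer chain, such as 2-phenylethyl, or a carboxylic acid in place of the methoxy group would read at this position.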